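From hydroxy to methoxy on compound 2

The source may report more compounds than this note shows. Statements on the series, on what has been measured and on what is new or still open speak of the compounds shown alone.

Compound 1 `COc1c(O)cc2cc1C[C@H](C)C[C@H](OC)[C@H](O)[C@@H](C)/C=C(\C)C[C@H](OC(N)=O)[C@@H](OC)CC/C=C(\C)C(=O)N2` gives 1760 nM
Compound 2 `COc1ccc([C@H]2c3cccc(c3O)NC(=O)/C(C)=C/C=C\[C@H](OC)[C@@H](OC(N)=O)/C(C)=C/[C@H](C)[C@@H](O)[C@@H](OC)C[C@@H]2C)cc1` gives 630 nM

In a functional assay on BGC-823 cells (Homo sapiens) for antiproliferative activity, read by MTT assay, with a stated time of 96 h (on this read-out higher numbers stand for weaker inhibition and lower numbers for stronger inhibition), compound 2 at 630 nM holds the lower of the two numbers, and its gap to compound 1 lies beyond the scatter. Compound 3 `COc1ccc([C@H]2c3cccc(c3O)NC(=O)/C(C)=C/C=C\[C@H](OC)[C@@H](OC(N)=O)/C(C)=C/[C@H](C)[C@@H](OC)[C@@H](OC)C[C@@H]2C)cc1` differs from compound 2 by one change, methyl in place of hydrogen on an oxygen on a saturated carbon with methyl in place of hydrogen on an oxygen on a saturated carbon, turning hydroxy into methoxy. Among the measured compounds shown here, no measured pair shows this change, so only a modest move toward weaker inhibition in this assay is expected. The estimated step is a 1.9-fold higher number from compound 2 to compound 3 (0.28 log units; within the scatter) in that direction. Compound 3 is expected at 1200 nM with 400 nM to 4000 nM as the estimated range.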

Compound 3, half-maximal inhibitory concentration: 6470 nM
Estimate against measurement, compound 3: 5.4-fold (0.73 log units) below; the measured number lies above the stated range.
By their numbers in this assay, from the lowest: compound 2; then compound 1; then compound 3.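

In this assay, among the compounds shown here, turning hydroxy into methoxy at this position gives a 10-fold higher number from compound 2 to compound 3 (1.01 log units; beyond the scatter), a step that the earlier compounds gave no way of sizing. It shows that this oxygen on a saturated carbon is sensitive to what it carries: one added methyl, with the rest of compound 2 unchanged, is enough to weaken inhibition markedly. Nothing given here bears on why the step is so large. The compounds shown leave open whether an amine or an ethoxy group at this place would track hydroxy or methoxy.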